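Lengthening the acid chain again in a leukotriene antagonist series

The source may hold more compounds than are shown below. What is called first, only, known or untested is meant among the compounds shown, and "the series" means these compounds.

Of the compounds shown here, three built on one shared core have been tested in a functional assay on ileum (Cavia porcellus) for inhibition of cysteinyl leukotriene receptor (Homo sapiens); on this read-out higher numbers stand for weaker inhibition and lower numbers for stronger inhibition. Compound 1 `CCCc1c(OCCCOc2cccc(OCC(=O)O)c2)ccc(C(C)=O)c1O` gives 500 nM. Compound 2 `CCCc1c(OCCCOc2c(C(C)=O)ccc(OCC(=O)O)c2CCC)ccc(C(C)=O)c1O` gives 2000 nM. Compound 3 `CCCc1c(OCCCOc2c(C(C)=O)ccc(OCCCC(=O)O)c2CCC)ccc(C(C)=O)c1O` gives 200 nM, the lowest of the three numbers and therefore the strongest inhibitor among them, standing clear of both others beyond the scatter. Among the compounds with values here, the only single-point change among the measured compounds is a 10-fold lower number from compound 2 to compound 3 (1.00 log units; beyond the scatter). Compound 4 `CCCc1c(OCCCOc2c(C(C)=O)ccc(OCCCCCC(=O)O)c2CCC)ccc(C(C)=O)c1O` repeats that same kind of change on the same chain: 2-carboxyethyl in place of carboxy on a saturated chain carbon, three bonds along the chain from an oxygen on an aromatic ring. Within the data shown here, only that one measured step speaks to the new compound, and it went in the direction of stronger inhibition; whether a second lengthening helps again, or whether the first one already brought the whole gain, cannot be read from three compounds. A smaller further gain is therefore expected, with a wide range on either side. For compound 4 the expected step is a 2.0-fold lower number from compound 3 to compound 4 (0.30 log units; within the scatter). Compound 4 is estimated at 100 nM, with a likely range from 30 nM to 400 nM.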

Compound 4, half-maximal inhibitory concentration: 1000 nM
The estimate for compound 4 lay 10-fold (1.00 log units) below the measured number; measured number above the stated range.
By their numbers in this assay, from the lowest: compound 3; then compounds 1, 4 and 2 (each within the scatter of the next, the first and the last beyond it).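

On this position the response to chain length does not run one way: in this assay the second lengthening, from 3-carboxypropyl to 5-carboxypentyl, brings a 5.0-fold higher number from compound 3 to compound 4 (0.70 log units; beyond the scatter) and so reverses the direction of the first. Set against the carboxymethyl chain, the 5-carboxypentyl chain gives a 2.0-fold lower number from compound 2 to compound 4 (0.30 log units; within the scatter) and the whole gain seen with 3-carboxypropyl is lost, so among these three compounds only the middle chain length stands out. Nothing available explains why inhibition weakens again at the longest chain. The compounds shown leave open how a 2-carboxyethyl or a 4-carboxybutyl chain would read on this core, so the best length could lie on either side of 3-carboxypropyl. They also leave open whether a chain longer than 5-carboxypentyl would continue the same trend.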